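Phenethyl on the sulfur of compound 2

The source may report more compounds than this note shows. Statements on the series, on what has been measured and on what is new or still open speak of the compounds shown alone.

For the measured compounds named here, in a functional assay on SMMC-7721 cells (Homo sapiens) for inhibition, read by CCK-8 assay, with a stated time of 72 h, tested at 2 uM (on this read-out higher numbers stand for more inhibition of growth at the one concentration tested and lower numbers for less inhibition of growth), compound 1 `CCc1ccc(SCc2ccc(/C=C/C(=O)Nc3ccccc3N)cc2)cc1` gives 13.2% and compound 2 `Nc1ccccc1NC(=O)/C=C/c1ccc(CSc2ccc(C(F)(F)F)cn2)cc1` gives 12.1%, which places compound 2 within the scatter of the only other measured compound. Compound 3 `Nc1ccccc1NC(=O)/C=C/c1ccc(CSCCc2ccccc2)cc1` keeps the shared core and differs from compound 2 in one group: phenethyl in place of 5-(trifluoromethyl)pyridin-2-yl on a sulfur. Here phenethyl stands in place of 5-(trifluoromethyl)pyridin-2-yl on a sulfur. Going by the values given here, one measured step bears on this sulfur, the exchange of 4-ethylphenyl for 5-(trifluoromethyl)pyridin-2-yl, and it amounts to a number 1.1 percentage points lower from compound 1 to compound 2 (within the scatter). Phenethyl itself has not been measured, so this single step offers only loose guidance, and no shift beyond the scatter is expected. The expected step is a number 1.9 percentage points higher from compound 2 to compound 3 (within the scatter). Compound 3 is estimated at 14%, with an expected range from 4% to 30%.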

Compound 3, percent growth inhibition at one concentration: 14.7%
The estimate for compound 3 lay 0.7 percentage points below the measured number; low and high end bracket the measured number.
By their numbers in this assay, from the lowest: compounds 2, 1 and 3 (each within the scatter of the next).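

In this assay the exchange for phenethyl gives a number 2.6 percentage points higher from compound 2 to compound 3 (within the scatter) and the exchange of 4-ethylphenyl for phenethyl gives a number 1.5 percentage points higher from compound 1 to compound 3 (within the scatter) on the same sulfur. For the compounds shown here, the earlier pair compared only two groups with their six-membered aromatic rings; phenethyl adds a third group, and the sulfur now also tolerates this group without a shift beyond the scatter. On this read-out, at the one concentration tested, the three groups cannot be told apart, and no measurement at hand explains why.

As far as these compounds go, whether any group on this sulfur can move the number beyond the scatter remains open, for example an amine or a carboxylic acid at the end of a longer chain. Whether the three compounds would also stay together at other concentrations is equally unsettled.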